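The source may hold more compounds than are shown below. What is called first, only, known or untested is meant among the compounds shown, and "the series" means these compounds.

In a functional assay on RT-112 cells (Homo sapiens) for antiproliferative activity, read by MTT assay, with a stated time of 72 h (a lower number here means a stronger inhibitor of growth, a higher number a weaker inhibitor of growth), compound 1 `COc1cc(Nc2ncnc3c(NC(=O)Nc4ccccc4Cl)cccc23)cc(OC)c1` gives 356 nM and compound 2 `COc1cc(Nc2ncnc3c(NC(=O)Nc4ccc(C(F)(F)F)cc4Cl)cccc23)cc(OC)c1` gives 1080 nM. Compound 2 therefore holds the higher of the two numbers and is the weaker growth inhibitor of this pair. Going by the values given here, the only measured step is a 3.0-fold higher number from compound 1 to compound 2 (0.48 log units; beyond the scatter), with trifluoromethyl in place of hydrogen on an aromatic carbon. That step is modest but beyond the usual scatter.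

Compound 3 `COc1cc(Nc2ncnc3c(NC(=O)c4cc(=O)c5ccccc5o4)cccc23)cc(OC)c1` differs from compound 2 in one place: a group of 11 heavy atoms (9 carbon, 2 oxygen; one six-membered aromatic ring of carbon only, one six-membered aromatic ring with 1 hetero atom) in place of a group of 12 heavy atoms (7 carbon, 1 nitrogen, 3 fluorine, 1 chlorine; one six-membered aromatic ring of carbon only), on a carbonyl carbon. The group that leaves is (2-chloro-4-(trifluoromethyl)phenyl)amino, and the group that enters has no common name. Among the compounds with values here, the measured step bears on this change only in part, since the trifluoromethyl goes but so does the rest of the group, and no measured compound carries the entering group. With the trifluoromethyl gone, and given a 3.0-fold higher number from compound 1 to compound 2 (0.48 log units; beyond the scatter), a modest move to a lower number is expected in this assay, with wide uncertainty. The estimated change is a 1.8-fold lower number from compound 2 to compound 3 (0.26 log units; within the scatter). For compound 3 the expected value is 600 nM, with an estimated range from 130 nM to 2800 nM.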

Compound 3, concentration for 50% growth inhibition: > 20000 nM
Compound 3: only a limit was reported; the forecaster's own chance of this, stated with the estimate: 10%; middle value at least 33-fold (1.52 log units) from the limit.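

In this assay, the group on this carbonyl carbon, whose other neighbour is an amide-type nitrogen, proves far more sensitive to change than the trifluoromethyl swap, which gave only a 3.0-fold higher number from compound 1 to compound 2 (0.48 log units; beyond the scatter). Putting the two-ring group in place of (2-chloro-4-(trifluoromethyl)phenyl)amino gives an at least 18-fold higher number from compound 2 to compound 3 (1.26 log units; beyond the scatter), and the comparison with the parent chlorinated compound gives an at least 56-fold higher number from compound 1 to compound 3 (1.74 log units; beyond the scatter), so both aryl amino groups shown are far better tolerated here than the entering group, although all three compounds keep the same core. The number for compound 3 is a limit of the assay and not a measured value: the limit of > 20000 nM in this assay, at which 1 of the 3 values shown sits.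

The change alters several things at once, as the nitrogen and its hydrogen-bond donor leave while a second ring and 2 hydrogen-bond acceptors enter, and the compounds shown cannot separate these differences or say how far beyond the limit compound 3 lies. A plain phenylamino group, a methylamino group or a phenyl group on the same carbonyl carbon would help show whether the nitrogen, the chlorine or the ring system carries the difference.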